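This account rests on a few compounds, and the source may have more. Where it says the series, first, only, none or still open, it means among the compounds named here.

In a functional assay on MOLT-4 cells (Homo sapiens) for cytotoxicity, read by sulforhodamine B assay, with a stated time of 48 h (on this read-out lower numbers stand for higher toxicity in this test and higher numbers for lower toxicity in this test), the measured compounds are these. Compound 1 `ClCc1ccc(Cn2cnc3c(Cl)ncnc32)cc1` gives only a limit of the assay, > 100000 nM. Compound 2 `ClCc1cccc(Cn2cnc3ncnc(Cl)c32)c1` gives 81300 nM. Compound 3 `ClCc1ccc(Cn2cnc3c(Cl)nc(Cl)nc32)cc1` gives 72400 nM.

Compound 3 arises from compound 1 by chloro in place of hydrogen on an aromatic carbon, and the result was an at least 1.3-fold lower number from compound 1 to compound 3 (0.14 log units; that floor lies within the scatter); because compound 1 sits at the limit of > 100000 nM in this assay, at which 1 of the 3 values shown sits, only a floor for that step is known. Compound 2 and compound 3 lie within the scatter of each other. The cores of compound 1 and compound 2 are built from the same atoms joined differently; that difference is not broken down here.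

Compound 4 `ClCc1cccc(Cn2cnc3nc(Cl)nc(Cl)c32)c1` is the not yet measured partner of compound 2, made by the same change, (chloro in place of hydrogen on an aromatic carbon). Resting on the step of an at least 1.3-fold lower number from compound 1 to compound 3 (0.14 log units; that floor lies within the scatter), the expected step is a 1.5-fold lower number from compound 2 to compound 4 (0.17 log units; within the scatter). Compound 4 is therefore estimated at 55000 nM, between 25000 nM and 120000 nM.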

Compound 4, concentration lethal to 50% of the cells: 5010 nM
Compound 4: middle estimate off by 11-fold (1.04 log units), on the high side; measured number below the stated range.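

In this assay, chloro in place of hydrogen on an aromatic carbon, between two ring nitrogen atoms, gave a 16-fold lower number from compound 2 to compound 4 (1.21 log units; beyond the scatter), so on this core the change brings a large step towards higher toxicity in this test. Compound 1 gives only a limit of the assay, > 100000 nM. The result therefore does not show whether the change has the same size on both cores or a different one: the same change on two cores in this assay, an at least 1.3-fold lower number (0.14 log units; that floor lies within the scatter) from compound 1 to compound 3 and a 16-fold lower number (1.21 log units; beyond the scatter) from compound 2 to compound 4; the limit leaves it open whether they differ

The compounds shown leave open whether another group on that same carbon, such as an amine or a methoxy group, would give a step of similar size. They also leave open whether the chloro step would be as large on any further core.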